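Terminal cap variation in a trifluoromethyl ketone elastase series

The source may report more compounds than this note shows. Statements on the series, on what has been measured and on what is new or still open speak of the compounds shown alone.

Measured compounds:
compound 1, `CC(C)[C@H](NC(=O)[C@@H]1CCCN1C(=O)[C@H](C)NC(=O)[C@H](C)NC(=O)OC(C)(C)C)C(=O)C(F)(F)F`, 44 nM
compound 2, `COC(=O)CCC(=O)N[C@@H](C)C(=O)N[C@@H](C)C(=O)N1CCC[C@H]1C(=O)N[C@H](C(=O)C(F)(F)F)C(C)C`, 14 nM

Both compounds share the same core and differ only in the group capping the terminal amide nitrogen. Within the data shown here, in an assay on isolated protein for binding affinity to chymotrypsin-like elastase family member 1 (Homo sapiens) (on this read-out lower numbers stand for stronger inhibition and higher numbers for weaker inhibition), compound 2 gives 14 nM, the lower of the two numbers; the only other number, for compound 1, sits a step away: a 3.1-fold lower number from compound 1 to compound 2 (0.50 log units; beyond the scatter). Compound 2 therefore stands as the stronger of the two, with a modest margin that nonetheless exceeds the scatter.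

Compound 3, `CC(C)[C@H](NC(=O)[C@@H]1CCCN1C(=O)[C@H](C)NC(=O)[C@H](C)NC(=O)OCc1ccccc1)C(=O)C(F)(F)F`, carries the change (benzyloxy in place of 2-(methoxycarbonyl)ethyl on a carbonyl carbon). Among the measured compounds shown here, the one measured step at this position is the one from compound 1 to compound 2, a 3.1-fold lower number from compound 1 to compound 2 (0.50 log units; beyond the scatter), which shows that the cap does shift the number, but only modestly. For the measured compounds named here, no step to a benzyloxy cap has been measured, so its direction cannot be read from the data. A shift of about the size seen for the cap so far, in either direction, is expected in this assay; the estimated step is a 2.1-fold higher number from compound 2 to compound 3 (0.33 log units; beyond the scatter). Compound 3 is expected to give about 30 nM, in a range from 8 nM to 120 nM.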

Compound 3, inhibition constant: 1 nM
The estimate for compound 3 lay 30-fold (1.48 log units) above the measured number, outside the stated range (below it).
By their numbers in this assay, from the lowest: compound 3; then compound 2; then compound 1.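

In this assay, the cap on the carbonyl carbon bonded to the amide-type nitrogen proves able to move the number much further than the earlier modest step suggested: a 14-fold lower number from compound 2 to compound 3 (1.15 log units; beyond the scatter), and a 44-fold lower number from compound 1 to compound 3 (1.64 log units; beyond the scatter). The second of these steps is the cleaner reading, since benzyl replaces tert-butyl on an oxygen next to a carbonyl group, so the change in the group on that oxygen alone is enough for a large step, and compound 3 now stands lowest of the three with both of its steps beyond the scatter. Nothing available gives a reason for the size of this shift.

The compounds shown leave open whether the step belongs to the aromatic ring of the benzyloxy cap or to the benzyloxy group as a whole, a question that a cyclohexylmethoxy cap, with a saturated ring in place of the aromatic one, or a longer phenylethoxy chain would help to settle. Also open, from the compounds shown here alone, is how a carboxylic acid in place of the methyl ester of compound 2 would read, and whether a benzyloxy cap gives a step of this size on any core other than the shared one.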